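Working notes: from compound 1 to compound 3

The source may report more compounds than this note shows. Statements on the series, on what has been measured and on what is new or still open speak of the compounds shown alone.

Measured so far:
compound 1, `CCSC(=S)SCC(=O)c1ccc(C)cc1`, gives 1250 nM
compound 2, `CCOC(=S)SCC(=O)c1ccc(OC)cc1`, gives 448 nM

Both values come from an assay on HEK293 cells for inhibition of protein deacetylase HDAC6 (Homo sapiens); on this read-out lower numbers stand for stronger inhibition and higher numbers for weaker inhibition. Compound 1 stands at the higher of the two numbers; compound 2 gives the lower number, and the gap between them lies beyond the usual scatter. No pair of these two differs in only one place, so no single step can be read off, and no cause for the gap is claimed.

Compound 3, `CCSC(=S)SCC(=O)c1ccc(CN(C)C(C)=O)cc1`, has not been measured in this assay. Against compound 1 the change is acetyl(methyl)amino in place of hydrogen on a saturated chain carbon bound to an aromatic carbon. The shared core and the rest of the molecule are kept.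

Nothing in the data tells how such an addition on a saturated chain carbon bound to an aromatic carbon moves the number in this assay. The expectation is therefore a modest step, with a slight lean toward a lower number, but not one that can be claimed beyond the scatter. The step from compound 1 to compound 3 is expected to be a 1.6-fold lower number from compound 1 to compound 3 (0.19 log units; within the scatter). For compound 3 the estimated value in this assay is 800 nM, with a range from 250 nM to 2500 nM.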

Compound 3, half-maximal inhibitory concentration: 256 nM
Compound 3: middle estimate off by 3.1-fold (0.49 log units), on the high side, within the range that was stated.
By their numbers in this assay, from the lowest: compounds 3 and 2 (each within the scatter of the next); then compound 1.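

In this assay, among the compounds shown here, acetyl(methyl)amino in place of hydrogen on a saturated chain carbon bound to an aromatic carbon gives a 4.9-fold lower number from compound 1 to compound 3 (0.69 log units; beyond the scatter), the only single-place step among the three compounds and one that lies beyond the scatter. It shows that this place accepts an addition of 5 heavy atoms, with no ring and no net charge, and that the number falls rather than rises, which compound 1 and compound 2 alone could not show. Compound 2 differs from the other two in more than one place, so no step to it can be read, and no available evidence bears on what lies behind the drop.

A single step leaves open whether the lower number needs the whole acetyl(methyl)amino group or only part of it, a question that a simple amine such as dimethylamino, a carboxylic acid or a longer chain on the same saturated chain carbon would address. Also open, as far as these compounds go, is whether the same addition moves the number to a similar extent when the rest of the molecule differs from that of compound 1.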